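This account rests on a few compounds, and the source may have more. Where it says the series, first, only, none or still open, it means among the compounds named here.

Among the measured compounds shown here, compound 1 `COc1ccc(C2C(C#N)=C(N)OC(c3c[nH]c4ccccc34)=C2C#N)cc1OC` gives 867 ug/mL in a functional assay (a higher number here means a weaker inhibitor, a lower number a stronger inhibitor), the only numeric value in this small set. Compound 2 `N#CC1=C(N)OC(c2c[nH]c3ccccc23)=C(C#N)C1c1ccccc1Cl` returns only an assay limit, > 1000 ug/mL. The step of an at least 1.1-fold higher number from compound 1 to compound 2 (0.06 log units; that floor lies within the scatter) therefore has a floor only, set by the limit of > 1000 ug/mL in this assay, at which 1 of the 2 values shown sits. Compound 3 `N#CC1=C(N)OC(c2c[nH]c3ccccc23)=C(C#N)C1c1cccc2ccccc12` differs from compound 1 by naphthalen-1-yl in place of 3,4-dimethoxyphenyl on a saturated ring carbon. For the measured compounds named here, the single measured exchange at this position is the only step bearing on it, and it moved toward the limit, so a further shift to a weaker inhibitor, or another limit, is the expectation in this assay. Compound 3 is expected at 1000 ug/mL, range 450 ug/mL to 2200 ug/mL, an expected step of a 1.2-fold higher number from compound 1 to compound 3 (0.06 log units; within the scatter).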

Compound 3, half-maximal inhibitory concentration: > 1000 ug/mL
Compound 3 ended at the assay's limit (the forecaster's own chance of this, stated with the estimate: 55%); the middle value sits exactly at the limit.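

In this assay, naphthalen-1-yl at the saturated ring carbon gives an at least 1.1-fold higher number from compound 1 to compound 3 (0.06 log units; that floor lies within the scatter), so this second exchange for 3,4-dimethoxyphenyl also yields no readable gain or loss. The step between compounds 2 and 3 cannot be read, as both values are limits, and compound 1 remains the only numeric anchor at this position: the limit of > 1000 ug/mL in this assay, at which 2 of the 3 values shown sit.

As far as these compounds go, how far compounds 2 and 3 lie past the limit remains open. Also open, from the compounds shown here alone, is whether a hydroxyl, a carboxylic acid or an aminomethyl group on the phenyl ring would give a value clearly different from compound 1.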